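Chloro for amino on the anilino ring of compound 3

The source may hold more compounds than are shown below. What is called first, only, known or untested is meant among the compounds shown, and "the series" means these compounds.

Compound 1 `O=S(=O)(c1ccccc1)c1nc2ccccc2nc1Nc1ccc(Cl)cc1`: 15300 nM
Compound 2 `COc1ccc(S(=O)(=O)c2nc3ccccc3nc2Nc2cc(OC)cc(OC)c2)cc1`: 6220 nM
Compound 3 `COc1ccc(S(=O)(=O)c2nc3ccccc3nc2Nc2ccc(N)cc2)cc1`: 9640 nM

In a functional assay on PC-3 cells (Homo sapiens) for cytotoxicity, read by MTT assay, with a stated time of 72 h (a lower number here means a stronger inhibitor, a higher number a weaker inhibitor), compound 3 gives 9640 nM, the second highest of the three numbers; compound 2 gives 6220 nM and compound 1 gives 15300 nM, both within the scatter of it. Compound 4 `COc1ccc(S(=O)(=O)c2nc3ccccc3nc2Nc2ccc(Cl)cc2)cc1` differs from compound 3 by chloro in place of amino on an aromatic carbon. Going by the values given here, the only step that changes this ring, a 1.5-fold higher number from compound 2 to compound 3 (0.19 log units; within the scatter), stayed within the scatter. Compound 1, which also carries a 4-chlorophenyl group, gives 15300 nM. Compound 4 is therefore expected to show no step beyond the scatter, a 1.1-fold higher number from compound 3 to compound 4 (0.06 log units; within the scatter), and is estimated at 11000 nM with a range of 4500 nM to 27000 nM.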

Compound 4, half-maximal inhibitory concentration: 31800 nM
For compound 4 the middle estimate is 2.9-fold (0.46 log units) below the measured one; measured number above the stated range.
By their numbers in this assay, from the lowest: compounds 2, 3 and 1 (each within the scatter of the next, the first and the last beyond it); then compound 4.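

In this assay, the position that carries the amino group of compound 3 is not indifferent to change: chloro in place of amino gives a 3.3-fold higher number from compound 3 to compound 4 (0.52 log units; beyond the scatter). The step from 3,5-dimethoxyphenyl to 4-chlorophenyl on the nitrogen gives a 5.1-fold higher number from compound 2 to compound 4 (0.71 log units; beyond the scatter), whereas the step to 4-aminophenyl stayed within the scatter, so the outcome depends on which group enters. With 4-chlorophenyl held fixed, methoxy in place of hydrogen on an aromatic carbon gives a 2.1-fold higher number from compound 1 to compound 4 (0.32 log units; beyond the scatter). No evidence here accounts for these steps. Going by these compounds, whether a hydroxyl, fluoro or methyl group at this same place would give a number closer to that of compound 3 or compound 4 remains open.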